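The compounds below may be only part of what the source reports. "The series", "measured", "known", "first", "only" and "open" are said of these compounds alone.

Measured compounds:
- compound 1, `O=C(Nc1ccccc1)c1cc2ccccc2oc1=O`: 760 nM
- compound 2, `O=C(Nc1ccccc1Cc1ccccc1)c1cc2ccccc2oc1=O`: 910 nM
- compound 3, `CC(C)CNC(=O)c1cc2ccc(OCc3ccccc3)cc2oc1=O`: 9590 nM

All numbers come from an in vitro assay on BTI-TN-5B1-4 cells for inhibition of Amine oxidase [flavin-containing] B (Homo sapiens), read by fluorescence; a lower number here means a stronger inhibitor, a higher number a weaker inhibitor. Compound 2 stands second highest of the three numbers. Its nearest neighbour is compound 1; the step of a 1.2-fold higher number from compound 1 to compound 2 (0.08 log units; within the scatter) lies within the scatter, so the two compounds cannot be ordered. Going by the values given here, compound 3 gives the highest number of the three, but it differs from compound 2 in more than one place, so no single-change step to it is available.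

Compound 4, `O=C(Nc1ccccc1Cc1ccccc1)c1cc2ccc(OCc3ccccc3)cc2oc1=O`, is the next compound in this assay. It differs from compound 2 by benzyloxy in place of hydrogen on an aromatic carbon. Among the compounds with values here, the only single-change step measured so far, a 1.2-fold higher number from compound 1 to compound 2 (0.08 log units; within the scatter), concerns a different position and was within the scatter, so it gives no direct guide. Compound 3, which also carries a benzyloxy group, shows a clearly higher number than compound 1 and compound 2, though its second difference leaves the attribution open. A rise in the number is therefore expected for compound 4, roughly a 3.3-fold higher number from compound 2 to compound 4 (0.52 log units; beyond the scatter). The estimate for compound 4 is 3000 nM, with a range from 900 nM to 10000 nM.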

Compound 4, half-maximal inhibitory concentration: 63500 nM
Estimate against measurement, compound 4: 21-fold (1.33 log units) below; the whole stated range lies below it.
By their numbers in this assay, from the lowest: compounds 1 and 2 (each within the scatter of the next); then compound 3; then compound 4.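

In this assay, going by these compounds alone, the step of a 70-fold higher number from compound 2 to compound 4 (1.84 log units; beyond the scatter) is the first single change that lies beyond the scatter, and it shows that benzyloxy in place of hydrogen at this position on the shared core weakens inhibition strongly. Within the data shown here, the earlier step, a 1.2-fold higher number from compound 1 to compound 2 (0.08 log units; within the scatter), put benzyl at a different place and could not be ordered, so this position is the first where a single change is seen to move the number. No measurement on hand accounts for the size of this step.

Among these compounds, only one group at this position has a single-change step, so it remains open whether a methoxy, a hydroxyl or an amine there would raise the number as far. Also open, as far as these compounds go, is whether benzyloxy would give a step of similar size on the core of compound 1, which lacks the benzyl group.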